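A few compounds are considered here, and "the series" means these few. Any claim that something is new, unique, unknown or untested is made for them only; others in the source may bear on it.

Measured so far in this series:
compound 1 `COc1ccc2cc(CO)oc(=O)c2c1` — 167 ug/mL
compound 2 `COc1ccc2cc(CCCO)oc(=O)c2c1` — 28.9 ug/mL

In a functional assay on U-251 cells (Homo sapiens) for antiproliferative activity, read by sulforhodamine B assay, with a stated time of 48 h (a lower number here means a stronger inhibitor of growth, a higher number a weaker inhibitor of growth), compound 1 gives 167 ug/mL and compound 2 gives 28.9 ug/mL. Among the measured compounds shown here, compound 2 holds the lowest number of the two measured, and its only neighbour is compound 1, so its standing rests on a single comparison. For the measured compounds named here, the one measured step is a 5.8-fold lower number from compound 1 to compound 2 (0.76 log units; beyond the scatter), a chain extension that kept the hydroxyl in place.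

Compound 3 `CCCCCOCCCc1cc2ccc(OC)cc2c(=O)o1` differs from compound 2 by pentyl in place of hydrogen on an oxygen on a saturated carbon. Going by the values given here, no measured step tests capping of the hydroxyl, so the step from compound 2 to compound 3 has no direct precedent; the step from compound 1 to compound 2 bears on it only loosely, in that adding carbon to the side chain coincided with a lower number. Carrying that over is uncertain, as the hydroxyl that both measured compounds share is now converted to an ether.

For compound 3 a modest further lowering is expected, mainly because a 5.8-fold lower number from compound 1 to compound 2 (0.76 log units; beyond the scatter) is the only direction the series has shown. The estimate for compound 3 is 15 ug/mL (range 4 ug/mL to 60 ug/mL), an expected 1.9-fold lower number from compound 2 to compound 3 (0.28 log units; within the scatter).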

Compound 3, concentration for 50% growth inhibition: 19.4 ug/mL
Estimate against measurement, compound 3: 1.3-fold (0.11 log units) below; measured number inside the range.
By their numbers in this assay, from the lowest: compounds 3 and 2 (each within the scatter of the next); then compound 1.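

In this assay, pentyl in place of hydrogen on the side-chain oxygen gives a 1.5-fold lower number from compound 2 to compound 3 (0.17 log units; within the scatter) and so does not separate the ether from the free alcohol. The free hydroxy shared by compound 1 and compound 2 is therefore not needed to keep the level seen with compound 2, and this oxygen accepts a pentyl group without a change that can be told from repeat measurement. This differs from the earlier change at the same side chain, a 5.8-fold lower number from compound 1 to compound 2 (0.76 log units; beyond the scatter), which lies beyond the scatter, and nothing at hand bears on why the pentyl cap leaves the number where it is.

The compounds shown leave open what an amine or a carboxylic acid at the end of the side chain would do in this assay, and whether a longer chain than pentyl on that oxygen would stay within the scatter of compound 2. They also leave open whether the same pentyl ether on the shorter side chain of compound 1 would give a number near that of compound 3 or near that of compound 1, so the effects of chain length and capping cannot yet be told apart.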